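The compounds below may be only part of what the source reports. "The series", "measured", "known", "first", "only" and "open" are said of these compounds alone.

In a functional assay on MDA-MB-231 cells (Homo sapiens) for inhibition, read by sulforhodamine B assay, with a stated time of 48 h (on this read-out higher numbers stand for weaker inhibition and lower numbers for stronger inhibition), compound 1 `CCOC(=O)CCO/N=C(/c1ccc(OC)c(OC)c1OC)c1cccc2ccccc12` gives 15200 nM as its reading and compound 3 `C=C(c1ccc(OC)c(OC)c1OC)c1cccc2ccccc12` gives 4660 nM on the same scale. Compound 2 `COc1ccc(C(OCc2ccccc2)c2cccc3ccccc23)c(OC)c1OC` gives > 20000 nM as a limit of the assay and not a number. Compound 4 `COc1ccc(C(OCc2ccc(C)cc2)c2cccc3ccccc23)c(OC)c1OC` differs from compound 2 by methyl in place of hydrogen on an aromatic carbon in the form of methyl in place of hydrogen on an aromatic carbon, para to a large group, which turns benzyl to 4-methylbenzyl. Among the compounds with values here, no measured pair shows this change. The expected step that the limit leaves unreadable from compound 2 to compound 4 is none beyond the scatter, in neither direction. In this assay compound 4 is estimated at 22000 nM with an expected range from 11000 nM to 45000 nM and may well read only as a limit.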

Compound 4, half-maximal inhibitory concentration: > 20000 nM
Compound 4: a limit, no number; the forecaster's own chance of this, stated with the estimate: 70%; the middle value lies beyond the limit too.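

Compound 2 and compound 4 both read only as limits, so no step can be read between them: the limit of > 20000 nM in this assay, at which 2 of the 4 values shown sit. On these data alone, whether benzyl to 4-methylbenzyl changes the reading at all, and in which direction, stays open.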